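The compounds below may be only part of what the source reports. "The series", "measured", "known", "first", "only" and "open" are said of these compounds alone.

Measured in a functional assay on HCT-116 cells (Homo sapiens) for inhibition, read by MTT assay, with a stated time of 72 h; a higher number here means a weaker inhibitor, a lower number a stronger inhibitor:
- compound 1 `CNC(=O)c1cc(Oc2ccc(Nc3nccc(N4CCCC4)n3)cc2)ccn1`: 1410 nM
- compound 2 `CNC(=O)c1cc(Oc2ccc(Nc3nccc(N4CCCCC4)n3)cc2)ccn1`: 540 nM

Of these two compounds, compound 2 has the lower number, 540 nM, which makes it the stronger inhibitor, and compound 1 is its nearest neighbour. Compound 3 `CNC(=O)c1cc(Oc2ccc(Nc3nccc(N4CCc5ccccc5C4)n3)cc2)ccn1` has 1,2,3,4-tetrahydroisoquinolin-2-yl in place of piperidin-1-yl on an aromatic carbon. Among the measured compounds shown here, only one measured step bears on this change: a 2.6-fold lower number from compound 1 to compound 2 (0.42 log units; beyond the scatter), a modest step made at the same place when piperidin-1-yl replaced pyrrolidin-1-yl. For the measured compounds named here, no measured compound carries the added aromatic ring, so that step is a weak guide. On the strength of it, a small further fall in this assay is expected, most likely within the scatter. The expected change is a 1.3-fold lower number from compound 2 to compound 3 (0.11 log units; within the scatter). The estimated value for compound 3 is 420 nM, with an expected range of 140 nM to 1300 nM.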

Compound 3, half-maximal inhibitory concentration: 15800 nM
Compound 3: middle estimate off by 38-fold (1.58 log units), on the low side; the measured number lies above the stated range.
By their numbers in this assay, from the lowest: compound 2; then compound 1; then compound 3.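

In this assay the gain from pyrrolidin-1-yl to piperidin-1-yl does not carry on at this aromatic carbon: 1,2,3,4-tetrahydroisoquinolin-2-yl in place of piperidin-1-yl gives a 29-fold higher number from compound 2 to compound 3 (1.47 log units; beyond the scatter) and thus reverses that gain. The same group also falls behind the smallest ring shown, with an 11-fold higher number from compound 1 to compound 3 (1.05 log units; beyond the scatter) on replacing pyrrolidin-1-yl, so the order of these three compounds is set by more than the step between the two simple rings could show. No measurement available here accounts for this loss.

As far as these compounds go, it remains open whether the loss comes from the fused aromatic ring as such or would also appear with an unfused benzyl group on the ring nitrogen of an open-chain amine. From the compounds shown here alone, how morpholin-4-yl or 4-methylpiperazin-1-yl would read at this carbon also remains open.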